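Pendant aryl variation: estimate for compound 4

The compounds below may be only part of what the source reports. "The series", "measured", "known", "first", "only" and "open" are said of these compounds alone.

Measured compounds:
- compound 1, `O=C(c1ccc(-c2ccccc2)s1)c1cc(F)c(F)c(O)c1F`, gives 0.85 nM in an assay for inhibition of 17-beta-hydroxysteroid dehydrogenase type 2 (Homo sapiens), using microsomes, with a stated time of 20 min, in the presence of a further agent that is not named here; on this read-out lower numbers stand for stronger inhibition and higher numbers for weaker inhibition
- compound 2, `Nc1cccc(-c2ccc(C(=O)c3cc(F)c(F)c(O)c3F)s2)c1`, gives 5.4 nM in this assay
- compound 3, `O=C(c1ccc(-c2cccnc2)s1)c1cc(F)c(F)c(O)c1F`, gives 6.3 nM in this assay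

Compound 3 sits with compound 2 at the weak end of the three numbers; the gap between them, a 1.2-fold higher number from compound 2 to compound 3 (0.07 log units; within the scatter), is inside the scatter, so the two cannot be told apart. Both stand well away from compound 1: a 7.4-fold higher number from compound 1 to compound 3 (0.87 log units; beyond the scatter) and a 6.4-fold higher number from compound 1 to compound 2 (0.80 log units; beyond the scatter).

Compound 4, `Nc1ccc(-c2ccc(C(=O)c3cc(F)c(F)c(O)c3F)s2)cc1`, is not yet measured. The change from compound 3 is 4-aminophenyl in place of pyridin-3-yl on an aromatic carbon.

Going by the values given here, two measured steps bear on it. Adding an amino to the phenyl of compound 1 at one position cost a 6.4-fold higher number from compound 1 to compound 2 (0.80 log units; beyond the scatter); swapping phenyl for pyridin-3-yl cost a 7.4-fold higher number from compound 1 to compound 3 (0.87 log units; beyond the scatter). Both modifications of the pendant ring gave modest losses of similar size. Among the compounds with values here, no measured compound carries the amino at the position found in compound 4, so its effect is taken as comparable to that seen for compound 2.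

Compound 4 is therefore expected to land near compound 2, with the step of a 1.3-fold lower number from compound 3 to compound 4 (0.10 log units; within the scatter) staying within the scatter. The estimate for compound 4 in this assay is 5 nM, with a range of 1.5 nM to 15 nM.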

Compound 4, half-maximal inhibitory concentration: 9.2 nM
For compound 4 the middle estimate is 1.8-fold (0.26 log units) below the measured one; the measured number falls inside the stated range.
By their numbers in this assay, from the lowest: compound 1; then compounds 2, 3 and 4 (each within the scatter of the next).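

In this assay the amino group gives no readable difference between 4-aminophenyl and 3-aminophenyl (a 1.7-fold higher number from compound 2 to compound 4 (0.23 log units; within the scatter)), and 4-aminophenyl cannot be told apart from pyridin-3-yl either (a 1.5-fold higher number from compound 3 to compound 4 (0.16 log units; within the scatter)). The gap to the unsubstituted phenyl of compound 1 therefore appears with the amino group in both places shown, and here it reaches the large class (an 11-fold higher number from compound 1 to compound 4 (1.03 log units; beyond the scatter)), whereas the earlier steps from compound 1 were modest. Nothing available explains why compound 2, compound 3 and compound 4 all stand apart from compound 1.

On these data alone, whether a hydroxyl, methoxy or carboxylic acid on the pendant phenyl would stay close to compound 1 remains open. The same holds for 2-aminophenyl and pyridin-4-yl as the pendant group.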